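The source may hold more compounds than are shown below. What is called first, only, known or untested is meant among the compounds shown, and "the series" means these compounds.

Measured so far:
Compound 1 `CNC(=O)/C=C/c1ccncc1-c1ccc2ccccc2c1`: in a functional assay on KB cells (Homo sapiens) for inhibition, read by sulforhodamine B assay, with a stated time of 72 h (a lower number here means a stronger inhibitor of growth, a higher number a weaker inhibitor of growth), compound 1 gives > 10000 nM, which is a limit of the assay rather than a number.
Compound 2 `O=C(/C=C/c1ccncc1-c1ccc2cc[nH]c2c1)N1CCOCC1`: compound 2 gives > 10000 nM, again a limit.
Compound 3 `Cn1ncc2cc(-c3cnccc3/C=C/C(=O)O)ccc21`: compound 3 gives > 10000 nM, also a limit.

Compound 1 thus has no position on a numerical scale: only a limit is recorded for it, the two further values are limits as well, and all three sit together at the limit of > 10000 nM in this assay, at which 3 of the 3 values shown sit. Among the compounds with values here, no step between measured compounds can be drawn from this set.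

Compound 4 `CN(C)C(=O)/C=C/c1ccncc1-c1ccc2ccccc2c1` differs from compound 1 by methyl in place of hydrogen on an amide-type nitrogen. With every recorded value resting at the limit, the step from compound 1 to compound 4 is expected to be none beyond the scatter, a step that the limit leaves unreadable from compound 1 to compound 4. The estimate for compound 4 in this assay is 20000 nM, with a range from 8000 nM to 60000 nM, and the expectation is that a limit is reported once more.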

Compound 4, concentration for 50% growth inhibition: 7760 nM
Beside the measured number, compound 4's estimate is 2.6-fold (0.41 log units) above it; the whole stated range lies above it.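

In this assay, within the data shown here, compound 4 gives 7760 nM, the only value so far that is a number and not a limit, so this amide-type nitrogen is a place where a change can bring the series onto the numerical scale. The change of hydrogen to methyl gives an at least 1.2-fold lower number from compound 1 to compound 4 (0.11 log units; that floor lies within the scatter), which is a bound and not a measured size. The true size of the step stays unknown, and the other values offer no number for comparison: the limit of > 10000 nM in this assay, at which 3 of the 4 values shown sit.

On these data alone, it remains open whether ethyl or a longer chain on this nitrogen would give a lower number than compound 4. As far as these compounds go, the effect of a carboxylic acid or an amine at the end of such a chain also remains open.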